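One group exchanged on a sulfur

A few compounds are considered here, and "the series" means these few. Any claim that something is new, unique, unknown or untested is made for them only; others in the source may bear on it.

- Compound 1 `C#CCSc1nc(Sc2nc(C)c(C)s2)c(C#N)c(-c2cc(OC)c(OC)c(OC)c2)n1`: > 20000 nM
- Compound 2 `C#CCSc1nc(Sc2nncs2)c(C#N)c(-c2cc(OC)c(OC)c(OC)c2)n1`: 4660 nM

Both readings come from a functional assay on SMMC-7721 cells (Homo sapiens) for antiproliferative activity, read by MTT assay, with a stated time of 72 h; a higher number here means a weaker inhibitor, a lower number a stronger inhibitor. The reading for compound 1 is a limit and not a number. Among the compounds with values here, compound 2 therefore holds the only true number so far, with nothing measured to rank it against except that limit.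

Compound 3 `C#CCSc1nc(Sc2nc[nH]n2)c(C#N)c(-c2cc(OC)c(OC)c(OC)c2)n1` has 1H-1,2,4-triazol-3-yl in place of 1,3,4-thiadiazol-2-yl on a sulfur.

Within the data shown here, the one measured step at that sulfur is an at least 4.2-fold lower number from compound 1 to compound 2 (0.63 log units; beyond the scatter). That step involves a different exchange and gives no direction for this one, so no step beyond the scatter is expected in this assay. The estimated change is a 1.3-fold higher number from compound 2 to compound 3 (0.11 log units; within the scatter). Compound 3 is expected at 6000 nM, with an estimated range of 2000 nM to 18000 nM.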

Compound 3, half-maximal inhibitory concentration: > 20000 nM
Compound 3 was reported as a limit (the forecaster's own chance of this, stated with the estimate: 20%); middle value at least 3.3-fold (0.52 log units) away from the limit.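

In this assay, placing 1H-1,2,4-triazol-3-yl in place of 1,3,4-thiadiazol-2-yl on this sulfur gives an at least 4.2-fold higher number from compound 2 to compound 3 (0.63 log units; beyond the scatter), so these two five-membered aromatic rings, each with the same count of hetero atoms, are not interchangeable at this position. Of the three groups shown on this sulfur, only the 1,3,4-thiadiazol-2-yl of compound 2 gives a true number, and the exchange in either direction that involves it is a step beyond the scatter. The step between compound 1 and compound 3 cannot be read, since each of these two readings is a limit: the limit of > 20000 nM in this assay, at which 2 of the 3 values shown sit.

From the compounds shown here alone, it remains open whether the hydrogen on the ring of 1H-1,2,4-triazol-3-yl matters to this result, which a 1-methyl-1H-1,2,4-triazol-3-yl group on the same sulfur could address. Going by these compounds, whether a 1,3,4-oxadiazol-2-yl group there would give a true number also stays open.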